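Chloro added to the sulfonyl aryl of a fluoroquinoline

The compounds below may be only part of what the source reports. "The series", "measured", "known", "first", "only" and "open" are said of these compounds alone.

Compound 2, `O=S(=O)(c1ccc(F)cc1)c1cnc2c(F)cccc2c1-c1cccc(F)c1`, gives the higher of the two numbers measured in an ADME assay on microsomes from liver (Homo sapiens) for metabolic stability, tested at 2.5 uM; a lower number here means slower removal, a higher number faster removal of the compound: compound 2 gives 1.56 mL/min, while compound 1, `O=S(=O)(c1ccc(F)c(Cl)c1)c1cnc2c(F)cccc2c1-c1ccc(F)cc1`, gives 0.19 mL/min, a gap well beyond the usual scatter. Compound 3, `O=S(=O)(c1ccc(F)c(Cl)c1)c1cnc2c(F)cccc2c1-c1cccc(F)c1`, has not yet been measured in this assay; it is related to compound 2 by a single change, (chloro in place of hydrogen on an aromatic carbon). Among the measured compounds shown here, compound 1 is the only measured compound that carries the same chloro group on that ring, and its value in this assay sits far under that of compound 2. On that basis alone, the step from compound 2 to compound 3 is expected to point downward, a 2.8-fold lower number from compound 2 to compound 3 (0.45 log units; beyond the scatter), though a step within the scatter cannot be ruled out. Compound 3 is therefore estimated at 0.55 mL/min in this assay, within a range from 0.2 mL/min to 1.5 mL/min.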

Compound 3, intrinsic clearance in a liver preparation (reported as CLH), per the amount of preparation that the assay uses: 1.23 mL/min
Estimate against measurement, compound 3: 2.2-fold (0.35 log units) below; measured number inside the range.
By their numbers in this assay, from the lowest: compound 1; then compounds 3 and 2 (each within the scatter of the next).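

In this assay, the change from 4-fluorophenyl to 3-chloro-4-fluorophenyl has no clear effect in this setting, with a 1.3-fold lower number from compound 2 to compound 3 (0.10 log units; within the scatter). Moving the fluoro instead matters far more: 3-fluorophenyl in place of 4-fluorophenyl gives a 6.5-fold higher number from compound 1 to compound 3 (0.81 log units; beyond the scatter), so of the two single changes now on record, only this one lies beyond the scatter. Nothing available explains this difference between the two changes.

Going by these compounds, the chloro step rests on one pair carrying 3-fluorophenyl, so whether chloro has the same small effect alongside 4-fluorophenyl stays open. Also open, on these data alone, is how a bromo, methyl or methoxy group in place of that chloro would behave, since only chloro and hydrogen are compared at this position.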